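The source may report more compounds than this note shows. Statements on the series, on what has been measured and on what is new or still open speak of the compounds shown alone.

Of the compounds shown here, two sharing one core have been measured in a functional assay for activation of Alpha-1A adrenergic receptor (Homo sapiens), read by calcium flux; a lower number here means that less compound is needed, a higher number that more compound is needed for the effect. Compound 1 `c1ccc(-c2cnoc2)c(NCC2=NCCN2)c1` gives 45.7 nM in this assay. Compound 2 `FC(F)(F)c1cccnc1-c1ccccc1NCC1=NCCN1` gives 676 nM in this assay. Of these two numbers, compound 1 stands lowest, and its gap to compound 2 lies beyond the scatter, so compound 1 clearly needs less material for the effect. The next step leads from compound 1 to compound 3 `CCO/N=C(\C)c1ccccc1NCC1=NCCN1`, which has not yet been measured. The change is a group of 6 heavy atoms (4 carbon, 1 nitrogen, 1 oxygen; no ring) in place of a group of 5 heavy atoms (3 carbon, 1 nitrogen, 1 oxygen; one five-membered aromatic ring with 2 hetero atoms), on an aromatic carbon. The aromatic ring goes, and an open chain carrying one double bond outside aromatic rings comes in its place, while the hydrogen-bond pattern stays as counted. Going by the values given here, no measured pair shows what such a change does in this assay, so the expectation rests on compound 1 alone, as the nearest measured point. Compound 3 is expected to give 120 nM in this assay, with a range from 40 nM to 400 nM. That estimate means a 2.6-fold higher number from compound 1 to compound 3 (0.42 log units; beyond the scatter), expected as a modest rise that sits close to the edge of the scatter.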

Compound 3, half-maximal effective concentration: 52.5 nM
For compound 3 the middle estimate is 2.3-fold (0.36 log units) above the measured one; measured number inside the range.
By their numbers in this assay, from the lowest: compounds 1 and 3 (each within the scatter of the next); then compound 2.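

In this assay, putting an open chain of 6 heavy atoms with one double bond at this aromatic carbon in place of the 1,2-oxazol-4-yl group gives a 1.1-fold higher number from compound 1 to compound 3 (0.06 log units; within the scatter). Going by these compounds alone, this is the first measured change at this position that shows a five-membered aromatic ring is not needed there to keep the number in the range of compound 1, since a group with no ring at all serves within the scatter, and both groups carry the same counts of hydrogen-bond donors and acceptors. Nothing measured here explains why these two different groups give matching numbers.

The compounds shown leave open how much of the entering group matters, for instance whether a shorter or longer chain, a plain amine or a carboxylic acid on the same aromatic carbon would give a similar number. They also leave open whether the match between these two groups would hold on another core or in any other test of the receptor.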